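Pyrrolidine substituent variations on the shared core

The compounds below may be only part of what the source reports. "The series", "measured", "known", "first", "only" and "open" are said of these compounds alone.

Measured compounds:
compound 1 `Cc1nn([C@H](C)c2ccc(Cl)cc2Cl)c2nc(N3CC[C@H](N4CCC4)[C@H](C)C3)cnc12` — 58 nM
compound 2 `Cc1nn([C@H](C)c2ccc(Cl)cc2Cl)c2nc(N3CC[C@H](N4CCC[C@H]4CCS(C)(=O)=O)[C@H](C)C3)cnc12` — 104 nM
compound 3 `Cc1nn([C@H](C)c2ccc(Cl)cc2Cl)c2nc(N3CC[C@H](N4CCC[C@H]4CCC(N)=O)[C@H](C)C3)cnc12` — 37 nM

In a functional assay on cells for antagonist activity at C-C chemokine receptor type 4 (Homo sapiens), read by fluorescence and calcium flux, with stated times of 2.5 s and 45 s (a lower number here means a stronger inhibitor, a higher number a weaker inhibitor), the three numbers sit close together. Compound 3 gives the lowest; its gap to compound 1, a 1.6-fold lower number from compound 1 to compound 3 (0.20 log units; within the scatter), is within the scatter, while the gap from compound 2, a 2.8-fold lower number from compound 2 to compound 3 (0.45 log units; beyond the scatter), lies beyond it.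

Compound 4 `Cc1nn([C@H](C)c2ccc(Cl)cc2Cl)c2nc(N3CC[C@H](N4CCC[C@H]4C(=O)O)[C@H](C)C3)cnc12` differs from compound 3 in that (carboxy in place of 2-carbamoylethyl on a saturated ring carbon). Within the data shown here, no measured step covers this change directly. The step of a 2.8-fold lower number from compound 2 to compound 3 (0.45 log units; beyond the scatter) shows that exchanging the group on the chain shifts the number only modestly, and a 1.6-fold lower number from compound 1 to compound 3 (0.20 log units; within the scatter) shows the pyrrolidine substituent itself matters little against the azetidine. The step of a 1.8-fold higher number from compound 3 to compound 4 (0.24 log units; within the scatter) is therefore expected to be small, within or near the scatter. For compound 4 the estimate is 65 nM, with a range of 22 nM to 190 nM.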

Compound 4, half-maximal inhibitory concentration: 670 nM
Compound 4: middle estimate off by 10-fold (1.01 log units), on the low side; the whole stated range lies below it.
By their numbers in this assay, from the lowest: compounds 3, 1 and 2 (each within the scatter of the next, the first and the last beyond it); then compound 4.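

In this assay, this position on the saturated ring carbon next to the ring nitrogen proves sensitive to the group it carries: carboxy in place of 2-carbamoylethyl gives a large step (an 18-fold higher number from compound 3 to compound 4 (1.26 log units; beyond the scatter)). Compound 4 also stands apart from the other two compounds (a 6.4-fold higher number from compound 2 to compound 4 (0.81 log units; beyond the scatter); a 12-fold higher number from compound 1 to compound 4 (1.06 log units; beyond the scatter)), whereas the substituents seen earlier stayed close together. No available evidence accounts for this rise.

From the compounds shown here alone, the change replaces the end group and removes the chain together, so their separate contributions stay open. Carboxy on a longer chain, or an amine at this place, would help to separate them.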